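A few compounds are considered here, and "the series" means these few. Any claim that something is new, unique, unknown or untested is made for them only; others in the source may bear on it.

Measured so far in an ADME assay on L6 cells (Rattus norvegicus) for cytotoxicity, read by resazurin assay, with a stated time of 72 h; a higher number here means a weaker inhibitor, a lower number a stronger inhibitor:
- Compound 1 `CCCC(=O)c1ccc2c(c1)/C(=C1\C(=O)N([C@@H]3O[C@H](COC(C)=O)[C@@H](OC(C)=O)[C@H](OC(C)=O)[C@H]3OC(C)=O)c3cc([N+](=O)[O-])ccc31)C(=O)N2`: 10700 nM
- Compound 2 `CC(=O)OC[C@H]1O[C@@H](N2C(=O)/C(=C3/C(=O)Nc4ncccc43)c3ccccc32)[C@H](OC(C)=O)[C@@H](OC(C)=O)[C@@H]1OC(C)=O`: 27400 nM
- Compound 3 `CC(=O)OC[C@H]1O[C@@H](N2C(=O)/C(=C3/C(=O)Nc4ncc(Br)cc43)c3ccccc32)[C@H](OC(C)=O)[C@@H](OC(C)=O)[C@@H]1OC(C)=O`: 26100 nM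

Compound 2 sits at the upper end of these numbers, within the scatter of compound 3, while compound 1 gives a clearly lower number. A higher number here means weaker inhibition of the cells, so compound 2 is among the milder members of this small set.

The next compound, compound 4 `CC(=O)OC[C@H]1O[C@@H](N2C(=O)/C(=C3/C(=O)Nc4ncccc43)c3cc(Br)ccc32)[C@H](OC(C)=O)[C@@H](OC(C)=O)[C@@H]1OC(C)=O`, is compound 2 with one small edit: bromo in place of hydrogen on an aromatic carbon. A bromo group takes the place of a hydrogen on an aromatic carbon, on the six-membered ring of carbon only.

Among the measured compounds shown here, one measured step bears on this. The same kind of swap, made elsewhere on the core, gave a 1.0-fold lower number from compound 2 to compound 3 (0.02 log units; within the scatter), which is no real change. That is a single example at a different place, and no bromo at the new place has been measured. For the measured compounds named here, compound 2 differs from compound 1 in more than one place, so compound 1 at 10700 nM offers no clean step, but it leaves room on the lower side.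

In this assay, the expected result is a 1.2-fold lower number from compound 2 to compound 4 (0.08 log units; within the scatter), a step not expected to exceed the scatter. For compound 4 the estimated value is 23000 nM, with an expected range of 12000 nM to 42000 nM.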

Compound 4, half-maximal inhibitory concentration: 10000 nM
For compound 4 the middle estimate is 2.3-fold (0.36 log units) above the measured one, and the stated range ends above it.
By their numbers in this assay, from the lowest: compounds 4 and 1 (each within the scatter of the next); then compounds 3 and 2 (each within the scatter of the next).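

In this assay, bromo in place of hydrogen on an aromatic carbon of the six-membered ring of carbon only gives a 2.7-fold lower number from compound 2 to compound 4 (0.44 log units; beyond the scatter). The same swap made elsewhere on the core gave a 1.0-fold lower number from compound 2 to compound 3 (0.02 log units; within the scatter), so in these two examples the place of the bromo matters: one step lies beyond the scatter and the other within it. A lower number here means stronger inhibition of the cells, so this new place is the first one at which a single small edit has moved the cytotoxicity reading of compound 2 at all, though only modestly, and no measurement shown offers a reason for the difference between the two places.

From the compounds shown here alone, it stays open whether this step belongs to bromo in particular or would also appear with another group on the same carbon, such as chloro, methoxy or an amine. Among the compounds shown here, also open is what a bromo at both places together would give, since each swap has been seen only on its own.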